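A few compounds are considered here, and "the series" means these few. Any claim that something is new, unique, unknown or untested is made for them only; others in the source may bear on it.

Measured in a functional assay on A549 cells (Homo sapiens) for inhibition, read by MTT assay, with a stated time of 96 h; on this read-out higher numbers stand for weaker inhibition of growth and lower numbers for stronger inhibition of growth:
Compound 1 `O=C(OCc1ccccc1)SCCCCCCNC(=O)c1cc(-c2ccncc2)n[nH]1`: 13400 nM
Compound 2 `CC(C)C(=O)SCCCCCCNC(=O)c1cc(-c2ccncc2)n[nH]1`: 16800 nM
Compound 3 `CCCCCCCC/C=C\CCCCCCCC(=O)SCCCCCCNC(=O)c1cc(-c2ccncc2)n[nH]1`: 33300 nM

All three compounds share one core and differ in the group on a carbonyl carbon whose other neighbour is sulfur. In this assay, compound 1 sits at the low end of these numbers, together with compound 2, so both stand on the stronger side of this small set. Compound 3 shows a higher number than compound 1, and that gap lies beyond the usual scatter.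

The next compound to be tested is compound 4 `CCC(=O)SCCCCCCNC(=O)c1cc(-c2ccncc2)n[nH]1`. Going there from compound 1 puts ethyl in place of benzyloxy on a carbonyl carbon.

Going by the values given here, the closest precedent is the swap of the same benzyloxy for isopropyl, another small group without a ring. That step, a 1.3-fold higher number from compound 1 to compound 2 (0.10 log units; within the scatter), was small. Among the compounds with values here, it is only one example, but it suggests that losing benzyloxy need not move the number much. No step beyond the scatter is therefore expected in this assay, and no clear direction can be called.

The estimate amounts to a 1.1-fold higher number from compound 1 to compound 4 (0.05 log units; within the scatter), an expected change that stays within the scatter. For compound 4 the expected value is 15000 nM, with an estimated range of 8000 nM to 28000 nM.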

Compound 4, concentration for 50% growth inhibition: > 50000 nM
Compound 4 gave a limit, no number (the forecaster's own chance of this, stated with the estimate: 3%); middle value at least 3.3-fold (0.52 log units) from the limit.
By their numbers in this assay, from the lowest: compounds 1, 2 and 3 (each within the scatter of the next, the first and the last beyond it). At a limit, above all of these: compound 4.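

In this assay compound 4 gives a limit and not a number: the limit of > 50000 nM in this assay, at which 1 of the 4 values shown sits. Swapping benzyloxy for a small group at this place on the carbonyl carbon can therefore matter a good deal, with an at least 3.7-fold higher number from compound 1 to compound 4 (0.57 log units; beyond the scatter), even though the earlier swap for isopropyl stayed small, with a 1.3-fold higher number from compound 1 to compound 2 (0.10 log units; within the scatter). The sharper lesson comes from a much smaller edit, hydrogen in place of methyl on a saturated chain carbon bound to a carbonyl carbon and a saturated chain carbon, which gives an at least 2.9-fold higher number from compound 2 to compound 4 (0.47 log units; beyond the scatter), so the loss of the aromatic ring alone does not separate compound 4 from the others, as compound 2 has no such ring either.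

As far as these compounds go, it remains open how other groups at this place would behave, such as methyl, butyl or cyclopropyl, and so whether compound 4 is a lone outlier or part of a wider trend with the size or branching of the group. The values shown give no reason for the gap, and they cannot tell how far compound 4 really lies from compound 2.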